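Shortening the Ketone Chain from Compound 3 to Compound 4

The source may report more compounds than this note shows. Statements on the series, on what has been measured and on what is new or still open speak of the compounds shown alone.

In an assay on isolated protein for binding affinity to histamine H2 receptor (Homo sapiens) (a lower number here means a stronger inhibitor, a higher number a weaker inhibitor), compound 3 `CCCCCCCCC(=O)c1ccc(OCCCN2CCN(C(=O)OCC)CC2)cc1` gives 2690 nM, the lowest of the three numbers measured. Compound 1 `CCCCCC(=O)c1ccc(OCCCN2CCN(C(=O)C3CCC3)CC2)cc1` gives 10200 nM and compound 2 `CCCCCC(=O)c1ccc(OCCCN2CCN(CC3CC3)CC2)cc1` gives 18600 nM; both lie beyond the scatter above compound 3, yet each differs from it in two places, so neither forms a single step with it. Within the data shown here, the only single step, a 1.8-fold higher number from compound 1 to compound 2 (0.26 log units; within the scatter), changes the group on the ring amine nitrogen, not the ketone chain, and so does not bear on the present change. Compound 4 `CCOC(=O)N1CCN(CCCOc2ccc(C(=O)CC(C)C)cc2)CC1` is compound 3 with isopropyl in place of heptyl on a saturated chain carbon bound to a carbonyl carbon. Among the measured compounds shown here, no measured step tests this shortening; the higher numbers of compound 1 and compound 2 hint weakly at a loss. Compound 4 is therefore expected to show a modest rise, a 2.4-fold higher number from compound 3 to compound 4 (0.38 log units; beyond the scatter), estimated at 6500 nM within 2000 nM to 20000 nM.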

Compound 4, inhibition constant: 69200 nM
Compound 4: middle estimate off by 11-fold (1.03 log units), on the low side; the measured number lies above the stated range.
By their numbers in this assay, from the lowest: compound 3; then compounds 1 and 2 (each within the scatter of the next); then compound 4.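

Replacing heptyl with isopropyl on a saturated chain carbon bound to a carbonyl carbon gives, in this assay, a 26-fold higher number from compound 3 to compound 4 (1.41 log units; beyond the scatter) and a large loss of affinity. Among these compounds, this is the first direct test of the ketone chain, and it shows that this single change can move the number well beyond the scatter. Nothing available explains the rise.

Heptyl and isopropyl differ in both length and branching, so the two remain unseparated. An unbranched propyl chain would test branching at that shorter length, while a chain longer than heptyl would show whether the trend continues.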